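Replacing the 2-isopropyl-1H-imidazol-1-yl group of compound 3

The source may report more compounds than this note shows. Statements on the series, on what has been measured and on what is new or still open speak of the compounds shown alone.

In a functional assay on HUVEC cells (Homo sapiens), read by scintillation counting and thymidine incorporation, with a stated time of 24 h (on this read-out lower numbers stand for stronger inhibition and higher numbers for weaker inhibition), compound 1 (`CCC(C)n1ncn(-c2ccc(N3CCN(c4ccc(OC[C@@H]5CO[C@@](CN6CCNCC6)(c6ccc(Cl)cc6Cl)O5)cc4)CC3)cc2)c1=O`) gives 608 nM and compound 2 (`CCC(C)n1ncn(-c2ccc(N3CCN(c4ccc(OC[C@@H]5CO[C@@](CN6CCN(C)CC6)(c6ccc(Cl)cc6Cl)O5)cc4)CC3)cc2)c1=O`) gives 396 nM, while compound 3 (`CCC(C)n1ncn(-c2ccc(N3CCN(c4ccc(OC[C@@H]5CO[C@@](Cn6ccnc6C(C)C)(c6ccc(Cl)cc6Cl)O5)cc4)CC3)cc2)c1=O`) gives 84 nM as the lowest of the three numbers. Compound 4 (`CCC(C)n1ncn(-c2ccc(N3CCN(c4ccc(OC[C@@H]5CO[C@@](Cn6cnc(C)c6)(c6ccc(Cl)cc6Cl)O5)cc4)CC3)cc2)c1=O`) has 4-methyl-1H-imidazol-1-yl in place of 2-isopropyl-1H-imidazol-1-yl on a saturated chain carbon bound to a saturated ring carbon. Two modest steps bring in the leaving group, namely a 7.2-fold lower number from compound 1 to compound 3 (0.86 log units; beyond the scatter) and a 4.7-fold lower number from compound 2 to compound 3 (0.67 log units; beyond the scatter) while a 1.5-fold lower number from compound 1 to compound 2 (0.19 log units; within the scatter) stays within the scatter. Among the measured compounds shown here, no measured pair varies the imidazole substituent itself. A modest move toward a higher number is therefore expected, and the estimated step is a 2.3-fold higher number from compound 3 to compound 4 (0.35 log units; beyond the scatter) in this assay for this change. Compound 4 is estimated at 190 nM with an expected range from 60 nM to 500 nM once measured.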

Compound 4, half-maximal inhibitory concentration: 102 nM
Compound 4: middle estimate off by 1.9-fold (0.27 log units), on the high side; the measured number falls inside the stated range.
By their numbers in this assay, from the lowest: compounds 3 and 4 (each within the scatter of the next); then compounds 2 and 1 (each within the scatter of the next).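

The step to 4-methyl-1H-imidazol-1-yl, a 1.2-fold higher number from compound 3 to compound 4 (0.08 log units; within the scatter), shows that the 2-isopropyl group is not needed to keep the number low at this place. Compound 4 stays clear of both piperazine compounds, with a 3.9-fold lower number from compound 2 to compound 4 (0.59 log units; beyond the scatter) and a 6.0-fold lower number from compound 1 to compound 4 (0.78 log units; beyond the scatter), so two differently substituted imidazoles now share this advantage over the two piperazines. Nothing available explains these numbers.

The compounds shown leave open whether the unsubstituted 1H-imidazol-1-yl group, a 1,2,4-triazol-1-yl group or a morpholin-4-yl group on this saturated chain carbon would stand with compound 3 and compound 4. They also leave open how each imidazole substituent acts alone, as the two differ in both identity and place on the ring.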